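This account rests on a few compounds, and the source may have more. Where it says the series, first, only, none or still open, it means among the compounds named here.

Compound 3 `COc1ccn2nc(C)c(C(=O)NCc3ccc(-c4ccc(OC(F)(F)F)cc4)c(C(F)(F)F)c3)c2c1` stands second highest of the three numbers in an ADME assay on Vero cells (Chlorocebus sabaeus) for cytotoxicity, with a stated time of 72 h (a lower number here means a stronger inhibitor, a higher number a weaker inhibitor), where compound 3 gives 11.6 ug/mL. Compound 2 `COc1ccn2nc(C)c(C(=O)NCc3ccc(-c4ccc(OC(F)(F)F)cc4)c(OC)c3)c2c1` gives 11.8 ug/mL, and compound 1 `COc1ccn2nc(C)c(C(=O)NCc3ccc(-c4ccc(OC(F)(F)F)cc4)c(C)c3)c2c1` gives 3.15 ug/mL. The measured steps are a 3.7-fold higher number from compound 1 to compound 3 (0.57 log units; beyond the scatter) and a 1.0-fold lower number from compound 2 to compound 3 (0.01 log units; within the scatter), with a 3.7-fold higher number from compound 1 to compound 2 (0.57 log units; beyond the scatter) alongside them. Compound 4 `COc1ccn2nc(C)c(C(=O)NCc3ccc(-c4ccc(OC(F)(F)F)cc4)c(F)c3)c2c1` differs from compound 3 by fluoro in place of trifluoromethyl on an aromatic carbon. For the measured compounds named here, no measured step exchanges trifluoromethyl for fluoro, so the bearing is indirect: methoxy and trifluoromethyl on this carbon give matching numbers, while methyl gives a lower one. A step of a 1.7-fold lower number from compound 3 to compound 4 (0.22 log units; within the scatter) is therefore expected, modest and toward a lower number. The estimate for compound 4 is 7 ug/mL, with a range from 3 ug/mL to 16 ug/mL.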

Compound 4, half-maximal inhibitory concentration: > 50 ug/mL
Compound 4: only a limit was reported; the forecaster's own chance of this, stated with the estimate: 5%; at least 7.1-fold (0.85 log units) between middle value and limit.
By their numbers in this assay, from the lowest: compound 1; then compounds 3 and 2 (each within the scatter of the next). At a limit, above all of these: compound 4.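

In this assay, fluoro on this carbon, ortho to a 4-(trifluoromethoxy)phenyl group, sets compound 4 apart from all three earlier compounds, with an at least 4.3-fold higher number from compound 3 to compound 4 (0.63 log units; beyond the scatter), an at least 4.2-fold higher number from compound 2 to compound 4 (0.62 log units; beyond the scatter) and an at least 15-fold higher number from compound 1 to compound 4 (1.20 log units; beyond the scatter). The earlier compounds shown here showed only that methyl differed from methoxy and trifluoromethyl, whereas this result shows that exchanging trifluoromethyl for fluoro also moves the number beyond the scatter. The number for compound 4 is a limit, not a measured value: the limit of > 50 ug/mL in this assay, at which 1 of the 4 values shown sits.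

As far as these compounds go, how far compound 4 lies past that limit stays open, as does whether chloro, hydrogen or an amine on this carbon would give a number like that of compound 4.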